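Working notes: iodo in place of thiophen-2-yl

The source may hold more compounds than are shown below. What is called first, only, known or untested is meant among the compounds shown, and "the series" means these compounds.

Measured in a functional assay on CCRF-CEM cells (Homo sapiens), read by MTT assay, with a stated time of 72 h; on this read-out higher numbers stand for weaker inhibition and lower numbers for stronger inhibition:
- compound 1 `CN(C)c1ncnc2c1c(-c1ccoc1)cn2[C@@H]1O[C@H](CO)[C@@H](O)[C@H]1O`: 13300 nM
- compound 2 `Nc1nc(N)c2c(-c3cccs3)cn([C@@H]3O[C@H](CO)[C@@H](O)[C@H]3O)c2n1`: > 20000 nM (a limit)
- compound 3 `Cc1nc(N)c2c(-c3cccs3)cn([C@@H]3O[C@H](CO)[C@@H](O)[C@H]3O)c2n1`: > 20000 nM (a limit)

Compound 3 sits at the limit of > 20000 nM in this assay, at which 2 of the 3 values shown sit, so it has no number, only a limit. Compound 4 `Cc1nc(N)c2c(I)cn([C@@H]3O[C@H](CO)[C@@H](O)[C@H]3O)c2n1` carries iodo in place of thiophen-2-yl on an aromatic carbon. For the measured compounds named here, no measured step covers this exchange. Going by the values given here, the only measured step, a step that the two limits leave unreadable from compound 2 to compound 3, gives no size to carry over. Among the compounds with values here, the one number is that of compound 1, at 13300 nM. With so little to go on, the expectation in this assay is a move towards stronger inhibition of uncertain size, and another limit remains quite possible. The expected change is an at least 2.8-fold lower number from compound 3 to compound 4 (0.45 log units; beyond the scatter). For compound 4 the estimate is 7000 nM, with an expected range of 1500 nM to 20000 nM.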

Compound 4, half-maximal inhibitory concentration: 9030 nM
Compound 4: the middle estimate sits 1.3-fold (0.11 log units) below what was measured; low and high end bracket the measured number.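

In this assay, for the compounds shown here, iodo in place of thiophen-2-yl gives an at least 2.2-fold lower number from compound 3 to compound 4 (0.34 log units; beyond the scatter), the first readable step at this aromatic carbon, so the group carried here does affect the read-out. A five-membered aromatic ring is not needed at this position for a measurable number: a single iodine atom, with no ring and no hydrogen-bond acceptor, suffices in compound 4. The size of this step is only a lower bound, since compound 3 carries a limit and not a number: the limit of > 20000 nM in this assay, at which 2 of the 4 values shown sit.

Going by these compounds, it remains open whether a bromo, an ethynyl or a short alkyl chain at this position would behave like iodo, which would separate the effect of iodine itself from the loss of the thiophen-2-yl ring. On these data alone, the step from compound 2 to compound 3 cannot be read, so whether amino or methyl is preferred on the other aromatic carbon also remains open.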